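Heteroaryl swap at the core in the cell assay

The source may report more compounds than this note shows. Statements on the series, on what has been measured and on what is new or still open speak of the compounds shown alone.

Three compounds of the series have numbers in a functional assay on CCRF-CEM cells (Homo sapiens) for inhibition; a lower number here means a stronger inhibitor, a higher number a weaker inhibitor. Compound 1 `Cn1cccc1-c1ncnc2c1ncn2C1O[C@H](CO)[C@@H](O)[C@H]1O` gives 2000 nM. Compound 2 `OC[C@H]1OC(n2cnc3c(-c4nccs4)ncnc32)[C@H](O)[C@@H]1O` gives 2730 nM, which is the second highest of the three numbers: nearest stands compound 1, furthest compound 3. Compound 3 `Cc1csc(-c2ncnc3c2ncn3C2O[C@H](CO)[C@@H](O)[C@H]2O)n1` gives 6000 nM. The steps measured so far are a 1.4-fold higher number from compound 1 to compound 2 (0.14 log units; within the scatter), a 3.0-fold higher number from compound 1 to compound 3 (0.48 log units; beyond the scatter) and a 2.2-fold higher number from compound 2 to compound 3 (0.34 log units; beyond the scatter).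

Compound 4 `OC[C@H]1OC(n2cnc3c(-c4ccsc4)ncnc32)[C@H](O)[C@@H]1O` is not yet measured. Relative to compound 2 the change is thiophen-3-yl in place of 1,3-thiazol-2-yl on an aromatic carbon. The step that bears most on this is the earlier exchange of one five-membered ring for another, a 1.4-fold higher number from compound 1 to compound 2 (0.14 log units; within the scatter), which stayed within the scatter; the steps to compound 3 concern a methyl and are less relevant. Going by the values given here, no measured pair shows the loss of a ring nitrogen at this carbon, so the direction is open. The expected step is therefore small, a 1.3-fold higher number from compound 2 to compound 4 (0.11 log units; within the scatter), at most a slight rise in the number. Compound 4 is estimated at 3500 nM, with a range of 1200 nM to 10000 nM.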

Compound 4, half-maximal inhibitory concentration: 1640 nM
Beside the measured number, compound 4's estimate is 2.1-fold (0.33 log units) above it; the measured number falls inside the stated range.
By their numbers in this assay, from the lowest: compounds 4, 1 and 2 (each within the scatter of the next); then compound 3.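

In this assay the ring nitrogen of 1,3-thiazol-2-yl proves dispensable at this aromatic carbon: thiophen-3-yl, with one hetero atom in place of two, gives a 1.7-fold lower number from compound 2 to compound 4 (0.22 log units; within the scatter) and so stays level with compound 2. Going by these compounds alone, the comparison with the 1-methyl-1H-pyrrol-2-yl group, a 1.2-fold lower number from compound 1 to compound 4 (0.09 log units; within the scatter), likewise shows no separation, whereas a 3.7-fold lower number from compound 3 to compound 4 (0.56 log units; beyond the scatter) leaves 4-methyl-1,3-thiazol-2-yl as the only group here set apart from the others, although compound 1 also carries a methyl and is not set apart. Nothing on hand gives a reason for these numbers.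

Still open, going by these compounds, is whether a methyl on the thiophen-3-yl ring would raise the number as it does on the 1,3-thiazol-2-yl ring. Also open, on these data alone, is how this carbon tolerates something other than a five-membered aromatic ring, such as a phenyl ring or an amine.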